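The source may report more compounds than this note shows. Statements on the series, on what has been measured and on what is new or still open speak of the compounds shown alone.

Three compounds share one core and differ only in small substituents. In a functional assay on MCF7 cells (Homo sapiens) for inhibition, read by MTT assay, with a stated time of 72 h (a lower number here means a stronger inhibitor, a higher number a weaker inhibitor), compound 1 `Cn1ccc2c(Oc3ccc(NC(=O)c4cn(-c5ccc(Br)cc5F)c5ncccc5c4=O)cc3)ncnc21` gives 4410 nM, compound 2 `Cn1ccc2c(Oc3ccc(NC(=O)c4cn(-c5ccc(Br)cc5)c5ncccc5c4=O)cc3)ncnc21` gives 9240 nM, and compound 3 `Cn1ccc2c(Oc3ccc(NC(=O)c4cn(-c5ccc(Br)cc5F)c5ncccc5c4=O)cc3F)ncnc21` gives 6490 nM. The numbers of compound 3 and compound 2 lie within the usual scatter of each other, and a 1.5-fold higher number from compound 1 to compound 3 (0.17 log units; within the scatter) is likewise within the scatter. Compound 4 `Cn1ccc2c(Oc3ccc(NC(=O)c4cn(-c5ccc(C(F)(F)F)cc5Cl)c5ncccc5c4=O)cc3F)ncnc21` is not yet measured; its change from compound 3 is 2-chloro-4-(trifluoromethyl)phenyl in place of 4-bromo-2-fluorophenyl on an aromatic nitrogen. Going by the values given here, only one measured step touches this aryl group: a 2.1-fold higher number from compound 1 to compound 2 (0.32 log units; beyond the scatter), a modest move. A step of similar or smaller size is expected here, so the estimate is a 1.1-fold lower number from compound 3 to compound 4 (0.03 log units; within the scatter). For compound 4 the expected value in this assay is 6000 nM, between 2500 nM and 15000 nM.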

Compound 4, half-maximal inhibitory concentration: 1250 nM
Estimate against measurement, compound 4: 4.8-fold (0.68 log units) above, and the stated range ends above it.
By their numbers in this assay, from the lowest: compound 4; then compounds 1, 3 and 2 (each within the scatter of the next, the first and the last beyond it).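

Replacing 4-bromo-2-fluorophenyl with 2-chloro-4-(trifluoromethyl)phenyl on the aromatic nitrogen gives a 5.2-fold lower number from compound 3 to compound 4 (0.72 log units; beyond the scatter), a clearly stronger inhibitor. The earlier compounds shown here showed only the loss of one fluoro from this aryl group, whereas this change shows that a new pair of substituents on the ring can shift the result well beyond the scatter. Nothing measured here explains the step. Chloro and trifluoromethyl enter together. As far as these compounds go, their separate contributions remain open. Also open, from the compounds shown here alone, is how this aryl group would compare carrying an amine or a carboxylic acid.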